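Dimethylamino for acetyl on the pendant phenyl

The source may report more compounds than this note shows. Statements on the series, on what has been measured and on what is new or still open speak of the compounds shown alone.

Compound 1 `COc1cc(C)cc(-c2c(-c3ccnc(-c4ccc(C(C)=O)cc4)c3)cnn2CC#N)c1` is read in a functional assay on SNB-75 cells (Homo sapiens) for cytotoxicity, read by sulforhodamine B assay, with a stated time of 48 h, tested at 100 nM (a higher number here means a weaker effect of the compound at the concentration tested, a lower number a stronger effect), where compound 1 gives 76%. Compound 2 `COc1cc(C)cc(-c2nn(CC#N)cc2-c2ccc(-c3cccc(C(C)=O)c3)nc2)c1` gives 79% in this assay, a number within the usual scatter of that of compound 1. Compound 3 `COc1cc(C)cc(-c2nn(CC#N)cc2-c2ccnc(-c3ccc(N(C)C)cc3)c2)c1`, which carries a dimethylamino group, gives -8%, far beyond the scatter below compound 1. Compound 4 `COc1cc(C)cc(-c2c(-c3ccnc(-c4ccc(N(C)C)cc4)c3)cnn2CC#N)c1` is compound 1 with one change: dimethylamino in place of acetyl on an aromatic carbon. For the measured compounds named here, no measured pair of the series shows this exact change on the core of compound 1, but the values of compound 1 and compound 3 point toward a large downward step. Compound 4 is therefore expected to reach 5%, with a range from -20% to 40%, an expected step of a number 71 percentage points lower from compound 1 to compound 4 (beyond the scatter).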

Compound 4, a percentage reported as activity, at one concentration (the size of the read-out at that concentration, not a potency): 6%
The estimate for compound 4 lay 1 percentage points below the measured number; low and high end bracket the measured number.
By their numbers in this assay, from the lowest: compound 3; then compound 4; then compounds 1 and 2 (each within the scatter of the next).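

In this assay, for the compounds shown here, the change from 4-acetylphenyl to 4-(dimethylamino)phenyl on the core of compound 1 gives a number 70 percentage points lower from compound 1 to compound 4 (beyond the scatter) as the first step with only one place changed. The earlier compounds shown here differed in more than one place, so this position alone is now seen to carry a large step. Nothing at hand bears on the cause of this step.
Open, as far as these compounds go, is whether a primary amine, a methoxy group or a morpholine ring at this place would give a similar step. Also open, from the compounds shown here alone, is whether the same change gives a similar step on the core of compound 2.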